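Acetyl for Methoxy on Two Related Urea Cores

The source may report more compounds than this note shows. Statements on the series, on what has been measured and on what is new or still open speak of the compounds shown alone.

Compound 1 `COc1ccccc1NC(=O)N[C@H](C)c1ccccc1` and compound 2 `COc1cccc(NC(=O)N[C@H](C)c2ccccc2)c1` are built from the same atoms joined differently; the difference between the two cores is not broken down here. In an ADME assay on the whole organism with Oryza sativa as the target, tested at 0.1 uM (a lower number here means a stronger effect, a higher number a weaker effect of the compound at the concentration tested), compound 1 gives 100% and compound 2 gives 104%. Compound 3 `CC(=O)c1ccccc1NC(=O)N[C@H](C)c1ccccc1` carries the change acetyl in place of methoxy on an aromatic carbon relative to compound 1, and in this assay compound 3 gives 96%, a step of a number 4 percentage points lower from compound 1 to compound 3 (within the scatter). Compound 4 `CC(=O)c1cccc(NC(=O)N[C@H](C)c2ccccc2)c1` carries the same kind of change on the core of compound 2, namely (acetyl in place of methoxy on an aromatic carbon); here the place is meta to a large group, whereas in compound 3 it is ortho to a large group. Because the step of a number 4 percentage points lower from compound 1 to compound 3 (within the scatter) lay within the scatter, compound 4 is expected to show a step of about a number 4 percentage points lower from compound 2 to compound 4 (within the scatter) in this assay. Compound 4 is therefore estimated at 100%, between 88% and 112%.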

Compound 4, a percentage reported as activity, at one concentration (the size of the read-out at that concentration, not a potency): 98%
Compound 4: the middle estimate sits 2 percentage points above what was measured, within the range that was stated.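

On the core of compound 2, acetyl in place of methoxy on an aromatic carbon gives a step of a number 6 percentage points lower from compound 2 to compound 4 (within the scatter) in this assay. Set beside the step on the core of compound 1, the result does not differ between the two cores: the same change on two cores in this assay, a number 4 percentage points lower (within the scatter) from compound 1 to compound 3 and a number 6 percentage points lower (within the scatter) from compound 2 to compound 4, 2 percentage points apart, within the scatter of two such steps Both steps lie within the scatter, so the agreement is between two results that cannot be told from no change, and it does not show that any real effect of this change carries from one core to the other.

The compounds shown leave open whether another group on that aromatic carbon, such as an amine or a carboxylic acid, would give a step beyond the scatter in this assay. Going by these compounds, whether a longer chain there would do so also remains open.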